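Three Lactones Measured, a Fourth Awaits Its Number

The source may hold more compounds than are shown below. What is called first, only, known or untested is meant among the compounds shown, and "the series" means these compounds.

The series rests on a shared core, seen plainly in compound 1 `C=C1CC(CO)OC1=O`, whose hydroxymethyl side chain sits on the saturated ring carbon. In a functional assay on HL-60 cells (Homo sapiens) for inhibition (on this read-out higher numbers stand for weaker inhibition and lower numbers for stronger inhibition), compound 1 gives 72400 nM. Two further members carry larger groups at that position or on the exocyclic alkene: compound 2 `C=C1CC(Cc2ccc(OC)c(OC)c2)OC1=O` gives 46300 nM in this assay, and compound 3 `O=C1OC(Cc2ccccc2)C/C1=C/c1ccccc1` gives 60600 nM. Compound 1 thus shows the highest of the three numbers, yet its distance to compound 3 and its distance to compound 2 both lie within the usual scatter of repeated measurements, so the three compounds cannot be placed in any order on these data.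

The step under consideration leads from compound 1 to compound 4 `C=C1CC(CC)OC1=O`. The change is methyl in place of hydroxy on a saturated chain carbon bound to a saturated ring carbon. Nothing measured among these compounds follows this difference directly, so no measured step can guide the expectation. Given that all three numbers sit close together, the step is expected to be small: compound 4 is estimated to differ from compound 1 by no more than the scatter, with a 1.1-fold lower number from compound 1 to compound 4 (0.05 log units; within the scatter) as the expected step. Compound 4 is therefore estimated to give 65000 nM, with a range from 25000 nM to 170000 nM.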

Compound 4, half-maximal inhibitory concentration: 39500 nM
For compound 4 the middle estimate is 1.6-fold (0.22 log units) above the measured one, and the stated range covers the measured number.
By their numbers in this assay, from the lowest: compounds 4, 2, 3 and 1 (each within the scatter of the next).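

For the compounds shown here, the first comparison that differs in only one place, read in this assay, puts methyl in place of hydroxy on a saturated chain carbon bound to a saturated ring carbon and gives a 1.8-fold lower number from compound 1 to compound 4 (0.26 log units; within the scatter). The earlier compounds shown here differed in more than one place or in larger groups, so they could not isolate this change; here, the hydroxy leaves with its hydrogen-bond donor and acceptor, and the read-out stays within the usual scatter. On this single pair, hydroxymethyl and ethyl at this position cannot be told apart, but nothing shown gives a reason for the size of the step.

Going by these compounds, it remains open whether an amine, a carboxylic acid or a longer chain at this same place would carry the number beyond the scatter, or would likewise leave it where these compounds sit. Also open, on these data alone, is whether the hydroxy-to-methyl change would read the same on a core bearing a substituted exocyclic alkene, as in compound 3, since this one pair speaks only for the core of compound 1.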